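Extending the Acetamide by One Carbon in Two Cores

The source may hold more compounds than are shown below. What is called first, only, known or untested is meant among the compounds shown, and "the series" means these compounds.

Measured compounds:
Compound 1, `CC(=O)Nc1ccc(-c2nc3cc(C(F)(F)F)ccc3n2C)cc1`: 15000 nM
Compound 2, `CC(=O)Nc1ccc(-c2nc3ccccc3[nH]2)cc1`: 100000 nM
Compound 3, `CCC(=O)Nc1ccc(-c2nc3cc(C(F)(F)F)ccc3n2C)cc1`: 8000 nM

All three were tested in an ADME assay on MT4 cells (Homo sapiens) for cytotoxicity, read by MTT assay, with a stated time of 96 h; a higher number here means that more compound is tolerated, a lower number that less compound is tolerated. Compound 1 gives 15000 nM, and compound 3, which differs from it only by methyl in place of hydrogen on a saturated chain carbon bound to a carbonyl carbon, gives 8000 nM; the step of a 1.9-fold lower number from compound 1 to compound 3 (0.27 log units; within the scatter) is small. Within the data shown here, compound 2 gives 100000 nM, the highest of the three numbers; the difference between its core and the core of compound 1 is not broken down here, and what can be said of the pair is only that compound 2 tolerates more than compound 1 in this assay.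

The unmeasured compound 4, `CCC(=O)Nc1ccc(-c2nc3ccccc3[nH]2)cc1`, stands to compound 2 as compound 3 stands to compound 1: the change is methyl in place of hydrogen on a saturated chain carbon bound to a carbonyl carbon, and it occurs twice among the compounds shown, on two different cores. Among the measured compounds shown here, since the one measured instance, a 1.9-fold lower number from compound 1 to compound 3 (0.27 log units; within the scatter), stayed within the usual scatter, compound 4 is expected to land close to compound 2, with a step of about a 1.4-fold lower number from compound 2 to compound 4 (0.15 log units; within the scatter) in this assay. That expectation rests on a single pair, and the core of compound 2 is not the core on which the step was measured, so the range is kept wide. Compound 4 is therefore estimated at 70000 nM, between 30000 nM and 150000 nM.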

Compound 4, half-maximal cytotoxic concentration: 35000 nM
Compound 4: the middle estimate sits 2.0-fold (0.30 log units) above what was measured; the range from low to high includes it.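

In this assay, the change from acetyl to propanoyl gives a 2.9-fold lower number from compound 2 to compound 4 (0.46 log units; beyond the scatter), a modest step that runs in the same direction as the one seen on the other core. Among these compounds, although only this new step lies beyond the scatter, the two steps do not differ from each other, so on these two cores the change carries over with much the same size: the same change on two cores in this assay, a 1.9-fold lower number (0.27 log units; within the scatter) from compound 1 to compound 3 and a 2.9-fold lower number (0.46 log units; beyond the scatter) from compound 2 to compound 4, 1.5-fold (0.18 log units) apart, within the scatter of two such steps This agreement rests on only two pairs in a single assay, so it does not show that the step would hold on any further core, and it does not separate the individual differences between the two cores.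

The compounds shown leave open what happens beyond propanoyl, whether a longer chain such as butanoyl would continue in the same direction or whether an amine or a carboxylic acid at the end of the chain would give a different result. They also leave open how the step would read on a core that carries only some of the differences between the core of compound 1 and the core of compound 2.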